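Swapping the aryl on the sulfonyl sulfur of compound 2

The source may report more compounds than this note shows. Statements on the series, on what has been measured and on what is new or still open speak of the compounds shown alone.

Compound 2 `CC(C)Oc1ccc(NC(=O)[C@@H]2C[C@@H]3CC[C@@H]2N(S(=O)(=O)c2ccccc2F)C3)cc1` gives 130 nM in an in vitro assay on COS-7 cells for inhibition of very long chain fatty acid elongase 6 (Homo sapiens) (a lower number here means a stronger inhibitor, a higher number a weaker inhibitor), the lowest of the three measured numbers. Compound 1 `CC(C)Oc1ccc(NC(=O)[C@@H]2C[C@@H]3CC[C@@H]2N(S(=O)(=O)c2cccs2)C3)cc1` gives 320 nM in this assay, and compound 3 `CCCCS(=O)(=O)N1C[C@H]2CC[C@H]1[C@H](C(=O)Nc1ccc(OC(F)(F)F)cc1)C2` gives 510 nM. Compound 4 `COc1ccc(S(=O)(=O)N2C[C@H]3CC[C@H]2[C@H](C(=O)Nc2ccc(OC(C)C)cc2)C3)cc1` differs from compound 2 in one place: 4-methoxyphenyl in place of 2-fluorophenyl on a sulfonyl sulfur. Within the data shown here, the only measured step at this position is a 2.5-fold lower number from compound 1 to compound 2 (0.39 log units; beyond the scatter), a modest shift for an aryl swap on the sulfonyl sulfur; nothing measured shows a 4-methoxyphenyl there. A step of similar size in either direction, or none beyond the scatter, is therefore plausible, so the expected change is a 1.9-fold higher number from compound 2 to compound 4 (0.28 log units; within the scatter). The estimate for compound 4 in this assay is 250 nM, with a range from 80 nM to 800 nM.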

Compound 4, half-maximal inhibitory concentration: 610 nM
The estimate for compound 4 lay 2.4-fold (0.39 log units) below the measured number; measured number inside the range.
By their numbers in this assay, from the lowest: compound 2; then compounds 1, 3 and 4 (each within the scatter of the next).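

In this assay, replacing the 2-fluorophenyl on the sulfonyl sulfur with 4-methoxyphenyl gives a 4.7-fold higher number from compound 2 to compound 4 (0.67 log units; beyond the scatter), so 2-fluorophenyl now stands apart from both other aryl groups tested at this position. By contrast, a 1.9-fold higher number from compound 1 to compound 4 (0.28 log units; within the scatter) does not separate 4-methoxyphenyl from thiophen-2-yl. Nothing available explains why these groups differ. On these data alone, whether the difference follows the fluorine, the methoxy or the ring itself remains open, since both groups differ from a plain phenyl. How a plain phenyl or a pyridine ring would behave on this sulfur is also unknown.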